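A few compounds are considered here, and "the series" means these few. Any claim that something is new, unique, unknown or untested is made for them only; others in the source may bear on it.

Measured so far:
compound 1, `CCCCC/C=C\C/C=C\C/C=C\C=C\C(CS)CCCC(=O)O`: 11000 nM
compound 2, `CCCCC/C=C\C/C=C\C/C=C\C=C\C(CCCC(=O)O)CC(=O)O`: 96000 nM

In an assay for inhibition of Polyunsaturated fatty acid 5-lipoxygenase (Rattus norvegicus) (on this read-out lower numbers stand for stronger inhibition and higher numbers for weaker inhibition), compound 2 gives 96000 nM, the higher of the two numbers, and compound 1 gives 11000 nM. Within the data shown here, the only measured step is an 8.7-fold higher number from compound 1 to compound 2 (0.94 log units; beyond the scatter), which runs from the lower number to the higher one.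

Compound 3, `CCCCC/C=C\C/C=C\C/C=C\C=C\C(CCCC(=O)O)NO`, is not yet measured. Its difference from compound 2 is hydroxyamino in place of carboxymethyl on a saturated chain carbon bound to a double-bonded chain carbon and a saturated chain carbon. Among the measured compounds shown here, no measured step covers a hydroxyamino group, and the one step in hand concerns a sulfanyl-to-carboxy exchange at a different chain carbon, so it is only a weak guide. Since compound 2 sits at the top of the two numbers, the expectation is a move back toward the value of compound 1, of the size an 8.0-fold lower number from compound 2 to compound 3 (0.90 log units; beyond the scatter). Compound 3 is estimated at 12000 nM in this assay, with a range from 2500 nM to 60000 nM.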

Compound 3, half-maximal inhibitory concentration: 21000 nM
The estimate for compound 3 lay 1.8-fold (0.24 log units) below the measured number, within the range that was stated.
By their numbers in this assay, from the lowest: compounds 1 and 3 (each within the scatter of the next); then compound 2.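

In this assay the exchange of carboxymethyl for hydroxyamino on a saturated chain carbon bound to a double-bonded chain carbon and a saturated chain carbon gives a 4.6-fold lower number from compound 2 to compound 3 (0.66 log units; beyond the scatter) and is the first step shown for a group carrying nitrogen at this place. Hydroxyamino in place of sulfanylmethyl at the same carbon gives a 1.9-fold higher number from compound 1 to compound 3 (0.28 log units; within the scatter) and leaves these two groups unseparated, so that among the three compounds only the carboxymethyl group of compound 2 stands apart from both others. Nothing measured here explains these differences.

Going by these compounds, what a plain amine or a hydroxymethyl group would give at this place stays open. So does whether a longer chain carrying the hydroxyamino group would shift the number in this assay at all.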